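Distal aryl changes on the hydroxyketone urea scaffold

This account rests on a few compounds, and the source may have more. Where it says the series, first, only, none or still open, it means among the compounds named here.

Compound 2 `Cc1ccc(CN2CCC(NC(=O)N(CC(=O)C(C)(C)O)Cc3ccc(-c4ccc(F)cc4)cc3)CC2)cc1` carries the hydroxyketone-substituted urea and a fluorinated distal ring. In an in vitro functional assay on HEK293 cells for antagonist activity at melanin-concentrating hormone receptor 1 (Homo sapiens), read by GTPgammaS binding, with a stated time of 45 min (on this read-out lower numbers stand for stronger inhibition and higher numbers for weaker inhibition), compound 2 gives 4530 nM. Compound 1 `COc1ccccc1-c1ccc(CNC(=O)NC2CCN(Cc3ccc(C)cc3)CC2)cc1` gives 642 nM in this assay, so compound 2 stands as the higher of the two numbers shown. Compound 3 `COc1ccc(-c2ccc(CN(CC(=O)C(C)(C)O)C(=O)NC3CCN(Cc4ccc(C)cc4)CC3)cc2)cc1` in this assay gives > 10000 nM, which is a limit of the assay and not a number (the limit of > 10000 nM in this assay, at which 1 of the 3 values shown sits).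

Among the measured compounds shown here, the only step measured at the distal ring is an at least 2.2-fold higher number from compound 2 to compound 3 (0.34 log units; beyond the scatter). Compound 4 `Cc1ccc(CN2CCC(NC(=O)N(CC(=O)C(C)(C)O)Cc3ccc(-c4cccc(C#N)c4)cc3)CC2)cc1` differs from compound 2 by 3-cyanophenyl in place of 4-fluorophenyl on an aromatic carbon. For the measured compounds named here, no measured pair carries a nitrile, so the bearing of that step is indirect: the one exchange on this ring moved the number upward, and compound 2 already sits high. The expected change is therefore small, a 1.2-fold higher number from compound 2 to compound 4 (0.08 log units; within the scatter), in the direction of a weaker number. Compound 4 is thus expected to give about 5500 nM, with a range from 2000 nM to 15000 nM.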

Compound 4, antagonist equilibrium constant: 5000 nM
The estimate for compound 4 lay 1.1-fold (0.04 log units) above the measured number, and the stated range covers the measured number.
By their numbers in this assay, from the lowest: compound 1; then compounds 2 and 4 (each within the scatter of the next). At a limit, above all of these: compound 3.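

The exchange of 4-fluorophenyl for 3-cyanophenyl brings in a nitrile and a hydrogen-bond acceptor on the distal ring, yet it gives a 1.1-fold higher number from compound 2 to compound 4 (0.04 log units; within the scatter), so this position accepts that exchange without a step beyond the scatter. Set against the 4-methoxyphenyl analogue, the series gives an at least 2.0-fold lower number from compound 3 to compound 4 (0.30 log units; that floor lies within the scatter), so compound 4 cannot be told apart from compound 3 on these numbers. The value of compound 3 is a limit of the assay and not a number: the limit of > 10000 nM in this assay, at which 1 of the 4 values shown sits.

The step to compound 4 alters the group and its place on the ring together, so the share of each stays unresolved. Going by these compounds, whether a carboxylic acid or an amine at this position would bring the number down also stays open.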